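A Chloro Group Removed from a Fused Aromatic Core

The source may report more compounds than this note shows. Statements on the series, on what has been measured and on what is new or still open speak of the compounds shown alone.

Measured compounds:
compound 1 `Clc1nc(Cl)c2c(ncn2C2COc3ccccc3CO2)n1` — 1250 nM
compound 2 `O=[N+]([O-])c1ccccc1S(=O)(=O)N1CC(n2cnc3c(Cl)ncnc32)OCc2ccccc21` — 2100 nM

Of the compounds shown here, two have so far been tested in a functional assay on MCF7 cells (Homo sapiens) for antiproliferative activity; a lower number here means a stronger inhibitor, a higher number a weaker inhibitor. Compound 1 `Clc1nc(Cl)c2c(ncn2C2COc3ccccc3CO2)n1` gives 1250 nM, the lowest of the two numbers. Compound 2 `O=[N+]([O-])c1ccccc1S(=O)(=O)N1CC(n2cnc3c(Cl)ncnc32)OCc2ccccc21` gives 2100 nM, and the gap between compound 1 and compound 2 lies within the usual scatter of repeated measurements, so neither can be ranked ahead of the other. For the measured compounds named here, no pair of measured compounds differs in a single place, so no measured step is available to calibrate what a small change to the core does.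

Compound 3 `Clc1ncnc2ncn(C3COc4ccccc4CO3)c12` remains to be measured. Compared with compound 1, the change is hydrogen in place of chloro on an aromatic carbon. A chloro group on the six-membered aromatic ring of the core is thus simply replaced by hydrogen, with nothing else altered.

Going by the values given here, with no measured step of this kind, the expectation rests on compound 1 alone. The step from compound 1 to compound 3 is expected to be a 1.8-fold higher number from compound 1 to compound 3 (0.25 log units; within the scatter), a modest move toward a higher number in this assay, though a step within the scatter is also plausible. Compound 3 is therefore estimated to give 2200 nM, within a range from 700 nM to 7000 nM.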

Compound 3, half-maximal inhibitory concentration: 1250 nM
The estimate for compound 3 lay 1.8-fold (0.25 log units) above the measured number, and the stated range covers the measured number.
By their numbers in this assay, from the lowest: compounds 1, 3 and 2 (each within the scatter of the next).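

In this assay, for the compounds shown here, replacing chloro with hydrogen on an aromatic carbon gives no change at the digits printed from compound 1 to compound 3 (within the scatter), the first step in this set that isolates a single change to the core. It shows that, with the rest of compound 1 held constant, the chloro group at this position between two ring nitrogen atoms is not needed to retain a number of this size. The result applies to this one position only, since compound 3 still keeps the other chloro group, meta to the position that changed. No measured evidence bears on why the exchange leaves the number as it is.

From the compounds shown here alone, compound 1 and compound 3 carry only chloro or hydrogen at this position, so what an amine, a methoxy group or a longer alkyl chain would do there remains open. Going by these compounds alone, it is equally open whether the remaining chloro group on compound 3 can be exchanged for hydrogen or for an amine with a similar outcome, as no single-place step at that position is available.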